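This account rests on a few compounds, and the source may have more. Where it says the series, first, only, none or still open, it means among the compounds named here.

Compound 1: `Cn1cccc1/C=N/N=C1\C[C@@H](c2ccc(O)cc2)Oc2cc(O)cc(O)c21` — >= 11300 nM
Compound 2: `COc1ccc([C@@H]2CC(=O)c3c(O)cc(OC)cc3O2)cc1` — >= 11300 nM

Compound 1, with the structure `Cn1cccc1/C=N/N=C1\C[C@@H](c2ccc(O)cc2)Oc2cc(O)cc(O)c21`, was tested in a functional assay on L5178Y cells (Mus musculus) for inhibition, read by MTT assay, with a stated time of 24 h (a higher number here means a weaker inhibitor, a lower number a stronger inhibitor), and gives >= 11300 nM, which is a limit of the assay rather than a measured number. Compound 2, with the structure `COc1ccc([C@@H]2CC(=O)c3c(O)cc(OC)cc3O2)cc1`, gives >= 11300 nM in this assay, and this too is only a limit. Compound 2 therefore stands where every value shown stands: the limit of >= 11300 nM in this assay, at which 2 of the 2 values shown sit. Neither result tells how weak either compound truly is beyond that point, and nothing separates the two.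

Compound 3 has the structure `COc1cc(O)c2c(c1)O[C@H](c1ccc(OCC(O)CCl)cc1)CC2=O`. It differs from compound 2 in a single place: 2-chloro-1-hydroxyethyl in place of hydrogen on a saturated chain carbon bound to an oxygen on an aromatic ring. Within the data shown here, no step between two measured compounds is available to show what adding this group does, so there is no basis for expecting a large shift in either direction. The step that the limit leaves unreadable from compound 2 to compound 3 is therefore expected to remain within the usual scatter. Compound 3 is estimated to give about 15000 nM in this assay, with a likely range from 5000 nM to 50000 nM, and it is expected that the assay will again report only a limit.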

Compound 3, half-maximal inhibitory concentration: >= 11300 nM
Compound 3 gave a limit, no number; the forecaster's own chance of this, stated with the estimate: 75%; the middle value lies beyond the limit too.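

In this assay compound 3 gives >= 11300 nM, which is a limit of the assay and not a number. Compound 2 also stands at a limit, so the step from compound 2 to compound 3 cannot be read. The compounds shown leave open how strongly each one inhibits, and whether 3-chloro-2-hydroxypropoxy in place of methoxy changes that at all.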